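Cyano on the biphenyl anilide of the benzoxaborole series

The source may report more compounds than this note shows. Statements on the series, on what has been measured and on what is new or still open speak of the compounds shown alone.

The shared core is the benzoxaborole bearing a propanamide chain; the amide partner varies. Compound 1 `CC(C)(C)NC(=O)CCc1cccc2c1B(O)OC2` carries a tert-butyl amide. In a functional assay on MDA-MB-231 cells (Homo sapiens) for antiproliferative activity, read by MTT assay, with a stated time of 72 h (on this read-out lower numbers stand for stronger inhibition and higher numbers for weaker inhibition), compound 1 gives > 100000 nM, which is a limit of the assay and not a number (the limit of > 100000 nM in this assay, at which 1 of the 2 values shown sits). Compound 2 `O=C(CCc1cccc2c1B(O)OC2)Nc1cccc(-c2ccccc2)c1` carries a biphenyl anilide. In this assay compound 2 gives 220 nM. This is the only number shown in the series, so compound 2 stands as the sole measured anchor and nothing can be said of its rank.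

Compound 3 `N#Cc1ccc(-c2cccc(NC(=O)CCc3cccc4c3B(O)OC4)c2)cc1` follows from compound 2 by a single change, (cyano in place of hydrogen on an aromatic carbon). Read one bond further out, the change is phenyl to 4-cyanophenyl. For the measured compounds named here, no step between measured compounds exists against which to weigh this change, so the direction rests on the change alone. A small step is expected here, likely within the scatter or a slight weakening, estimated as a 1.5-fold higher number from compound 2 to compound 3 (0.16 log units; within the scatter). Compound 3 is therefore expected to give 320 nM, with a range from 100 nM to 1000 nM.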

Compound 3, half-maximal inhibitory concentration: 380 nM
Compound 3: middle estimate off by 1.2-fold (0.07 log units), on the low side, and the stated range covers the measured number.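

Cyano in place of hydrogen on an aromatic carbon, para to a large group, gives a 1.7-fold higher number from compound 2 to compound 3 (0.24 log units; within the scatter) in this assay, so compound 2 and compound 3 cannot be told apart on this read-out. For the compounds shown here, until now the series offered a single measured number, with no reading of any change on the biphenyl anilide; this step is the first, and it shows that this position accepts a cyano group, with its triple bond and one hydrogen-bond acceptor, without a separation from the parent compound. Nothing at hand bears on why the step is this small.

From the compounds shown here alone, one group at one place cannot show how far this tolerance reaches, so an amine, a carboxylic acid or a methoxy group at the same carbon remains open, as does the same cyano group on another carbon of that ring. Also open is whether the result holds with a longer chain in place of the propanamide chain, since every compound shown carries that same chain.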